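Capping a Phenol: Hydroxy to Methoxy on Compound 2

The compounds below may be only part of what the source reports. "The series", "measured", "known", "first", "only" and "open" are said of these compounds alone.

Of the compounds shown here, two have been tested in a functional assay on UACC-62 cells (Homo sapiens) for inhibition, read by sulforhodamine B assay, with a stated time of 48 h, tested at 1 uM; on this read-out lower numbers stand for a stronger effect and higher numbers for a weaker effect at the one concentration tested. Compound 1 `COc1cc(Cl)cc(-c2nn(-c3cccc(NC(=O)c4cccc(C(F)(F)F)c4)c3)cc2-c2ccncc2)c1` gives 56%. Compound 2 `O=C(Nc1cccc(-n2cc(-c3ccncc3)c(-c3cc(O)cc(Cl)c3)n2)c1)Nc1ccc(Cl)c(Cl)c1` gives 83%, the higher of the two numbers, standing above compound 1 by a margin beyond the usual scatter. Compound 3 `COc1cc(Cl)cc(-c2nn(-c3cccc(NC(=O)Nc4ccc(Cl)c(Cl)c4)c3)cc2-c2ccncc2)c1` has not yet been measured and differs from compound 2 in one place: methyl in place of hydrogen on an oxygen on an aromatic ring. Among the compounds with values here, no measured pair shows this exact change, so its effect is open. A modest downward step is expected, close to the edge of the scatter, which means an estimated a number 13 percentage points lower from compound 2 to compound 3 (beyond the scatter). Compound 3 is expected to give about 70%, within a range from 45% to 95%.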

Compound 3, a percentage reported as activity, at one concentration (the size of the read-out at that concentration, not a potency): 75%
Compound 3: the middle estimate sits 5 percentage points below what was measured, and the stated range covers the measured number.
By their numbers in this assay, from the lowest: compound 1; then compounds 3 and 2 (each within the scatter of the next).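

In this assay the step from hydroxy to methoxy gives a number 8 percentage points lower from compound 2 to compound 3 (within the scatter), so at this position on the 3-chloro-5-hydroxyphenyl group, capping the oxygen with methyl produces no readable change. With the methoxy kept, (3,4-dichlorophenyl)amino in place of 3-(trifluoromethyl)phenyl on the carbonyl carbon gives a number 19 percentage points higher from compound 1 to compound 3 (beyond the scatter), a difference that does stand out. Nothing available explains either result. Still open, as far as these compounds go, is how an amine in place of the hydroxy, or a longer chain such as ethyl on the oxygen, would read here.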